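Phenylpropanoic acid series: 4-methylphenyl in place of trifluoromethyl

The compounds below may be only part of what the source reports. "The series", "measured", "known", "first", "only" and "open" are said of these compounds alone.

Measured so far:
compound 1, `N#Cc1cccc(COc2ccc(CCC(=O)O)cc2)c1`, gives 102% in a functional assay on 1321-N1 cells for agonist activity at Free fatty acid receptor 1 (Homo sapiens), read by calcium flux; a higher number here means a larger maximal response, a lower number a smaller maximal response.
compound 2, `O=C(O)CCc1ccc(OCc2cccc(C(F)(F)F)c2)cc1`, gives 103% in this assay.
compound 3, `O=C(O)CCc1ccc(NCc2ccccc2-c2ccccc2)cc1`, gives 97% in this assay.

Compound 2 holds the highest of the three numbers in this assay, yet all three sit within the scatter of one another, so no order can be read from them.

Compound 4, `Cc1ccc(-c2cccc(COc3ccc(CCC(=O)O)cc3)c2)cc1`, differs from compound 2 as follows: 4-methylphenyl in place of trifluoromethyl on an aromatic carbon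

Among the compounds with values here, the only measured step at this position is a number 1 percentage points higher from compound 1 to compound 2 (within the scatter), and it stayed within the scatter. Compound 3 carries a large group at a comparable position and shows a similar number. The change to compound 4 is therefore expected to leave this assay essentially unchanged, with a number 3 percentage points lower from compound 2 to compound 4 (within the scatter) as the expected step.

Compound 4 is estimated at 100%, within 85% to 115%.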

Compound 4, largest response reached (reported as efficacy), in percent of the reference or control that the assay uses: 86%
The estimate for compound 4 lay 14 percentage points above the measured number, and the stated range covers the measured number.
By their numbers in this assay, from the lowest: compound 4; then compounds 3, 1 and 2 (each within the scatter of the next).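

In this assay, this aromatic carbon does not tolerate every group equally: 4-methylphenyl gives a number 17 percentage points lower from compound 2 to compound 4 (beyond the scatter) and a number 16 percentage points lower from compound 1 to compound 4 (beyond the scatter). Within the data shown here, the only earlier exchange here, trifluoromethyl for cyano, gave a number 1 percentage points higher from compound 1 to compound 2 (within the scatter), so a real difference in maximal response appears only with the added aromatic ring. No measurement at hand accounts for this difference.

Still open, on these data alone, is whether the ring itself or its methyl group goes with the lower response. An unsubstituted phenyl or a pyridine ring at this carbon would bear on that question.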